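Amino in place of bromo: expected tolerance of compound 4

A few compounds are considered here, and "the series" means these few. Any claim that something is new, unique, unknown or untested is made for them only; others in the source may bear on it.

Among the compounds with values here, in an ADME assay on Huh-7 cells (Homo sapiens) for cytotoxicity (a higher number here means that more compound is tolerated, a lower number that less compound is tolerated), compound 3 `Cc1ccccc1-c1nn(-c2ccc(Br)cc2)cc1CNCCN1CCN(C)CC1` gives 9600 nM, the only value of the set reported as a number. Compound 1 `Cc1ccccc1-c1nn(-c2ccccc2Cl)cc1CNCCN1CCN(C)CC1` reaches only a limit, > 20000 nM. Compound 2 `Cc1ccccc1-c1nn(-c2ccc(F)cc2F)cc1CNCCN1CCN(C)CC1` likewise reaches only a limit, > 20000 nM. Compound 4 `Cc1ccccc1-c1nn(-c2ccc(N)cc2)cc1CNCCN1CCN(C)CC1` differs from compound 3 by amino in place of bromo on an aromatic carbon. No measured step makes this exchange itself; the steps that bear on it are an at least 2.0-fold lower number from compound 1 to compound 3 (0.31 log units; beyond the scatter) and an at least 2.0-fold lower number from compound 2 to compound 3 (0.31 log units; beyond the scatter), both replacing another aryl group by 4-bromophenyl, and together with the limit of > 20000 nM in this assay, at which 2 of the 3 values shown sit, they leave compound 3 with the lowest number shown. Because of an at least 2.0-fold lower number from compound 1 to compound 3 (0.31 log units; beyond the scatter) the author expects removing bromo to raise the number for compound 4, a step of a 2.1-fold higher number from compound 3 to compound 4 (0.32 log units; beyond the scatter). Compound 4 is therefore estimated at 20000 nM, within a range from 9000 nM to 45000 nM.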

Compound 4, half-maximal cytotoxic concentration: > 20000 nM
Compound 4 gave a limit, no number; the forecaster's own chance of this, stated with the estimate: 50%; the middle value lies on the limit itself.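

In this assay, the bromo group itself now proves to matter on an aromatic carbon para to a large group: amino in place of bromo gives an at least 2.0-fold higher number from compound 3 to compound 4 (0.31 log units; beyond the scatter). The earlier steps shown here exchanged a whole aryl group on an aromatic nitrogen, whereas this one changes a single group, and compound 4 ends at a limit, not a number: the limit of > 20000 nM in this assay, at which 3 of the 4 values shown sit. The steps from compound 1 and compound 2 to compound 4 join two limits and cannot be read.

As far as these compounds go, the true size of the step from bromo to amino stays open. So does whether a chloro group, a methoxy group or a carboxylic acid at this place would give a number or a limit.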